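From cyclopropylsulfonyl to (4-chlorophenyl)carbamoyl on compound 3

The source may report more compounds than this note shows. Statements on the series, on what has been measured and on what is new or still open speak of the compounds shown alone.

In a functional assay on MDA-MB-231 cells (Homo sapiens) for antiproliferative activity, read by MTT assay, with a stated time of 48 h (a lower number here means a stronger inhibitor, a higher number a weaker inhibitor), compound 3 `CN1CCN(c2ccc(-c3cc4c(N5CCN(S(=O)(=O)C6CC6)CC5)ncnc4s3)cc2)CC1` gives 11500 nM, the lower of the two numbers available. Compound 1 `C=CS(=O)(=O)N1CCN(c2ncnc3sc(-c4ccnc(Cl)c4)cc23)CC1` gives 27700 nM. Compound 2 `C=CS(=O)(=O)N1CCN(c2ncnc3sc(C4=CCCCC4)cc23)CC1` reads > 50000 nM, which is a limit of the assay and not a number.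

The next structure, compound 4 `CN1CCN(c2ccc(-c3cc4c(N5CCN(C(=O)Nc6ccc(Cl)cc6)CC5)ncnc4s3)cc2)CC1`, carries (4-chlorophenyl)carbamoyl in place of cyclopropylsulfonyl on an amine nitrogen in a ring. Going by the values given here, the only measured step between close neighbours, an at least 1.8-fold higher number from compound 1 to compound 2 (0.25 log units; that floor lies within the scatter), puts cyclohex-1-en-1-yl in place of 2-chloropyridin-4-yl on an aromatic carbon. That step lies at another place and its floor stays within the scatter, so it gives no size for a change on the amine nitrogen. Among the compounds with values here, no measured step covers that nitrogen. The series thus gives no direction in this assay, and no shift beyond the scatter is expected, though the range has to stay wide. The expected step is a 1.2-fold lower number from compound 3 to compound 4 (0.06 log units; within the scatter). For compound 4 the estimated value is 10000 nM, with an expected range from 3000 nM to 35000 nM.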

Compound 4, half-maximal inhibitory concentration: 5440 nM
Estimate against measurement, compound 4: 1.8-fold (0.26 log units) above; low and high end bracket the measured number.
By their numbers in this assay, from the lowest: compound 4; then compound 3; then compound 1. At a limit, above all of these: compound 2.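

In this assay, the amine nitrogen in the six-membered non-aromatic ring with 2 nitrogen now has a measured step of its own, and that step lies beyond the scatter, though it is modest: a 2.1-fold lower number from compound 3 to compound 4 (0.33 log units; beyond the scatter). Going by these compounds alone, the earlier compounds gave only a step on an aromatic carbon, with a floor inside the scatter, so this is the first readable change and it shows that the amine nitrogen can carry the larger (4-chlorophenyl)carbamoyl in place of cyclopropylsulfonyl with a lower number. The swap changes several things at once: a six-membered aromatic ring of carbon only and a hydrogen-bond donor enter, while a three-membered ring and the sulfonyl leave, and nothing shown bears on which of these accounts for the step.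

A phenylcarbamoyl group without the chlorine, or a phenylsulfonyl group, would separate the aromatic ring from the linking carbonyl and from the chlorine. Also open, going by these compounds, is whether a shorter acyl such as acetyl, or a basic amine at the end of a longer chain on this nitrogen, would move the number further in either direction.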